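This account rests on a few compounds, and the source may have more. Where it says the series, first, only, none or still open, it means among the compounds named here.

Working notes on the series. Three compounds share a core and differ only in the group on an oxygen on the aromatic ring. Compound 1 `CN(c1ccc([N+](=O)[O-])cc1OC1CCCCC1)S(C)(=O)=O` carries cyclohexyl there and gives 470 nM in an assay on SK-BR-3 cells for inhibition of Aromatase (Homo sapiens); a lower number here means a stronger inhibitor, a higher number a weaker inhibitor. Compound 2 `CC(C)Oc1cc([N+](=O)[O-])ccc1N(C)S(C)(=O)=O` carries isopropyl and gives 2810 nM in this assay. Compound 3 `CN(c1ccc([N+](=O)[O-])cc1OC1CCCC1)S(C)(=O)=O` carries cyclopentyl and gives 440 nM in this assay. The two ring-bearing compounds sit together: a 1.1-fold lower number from compound 1 to compound 3 (0.03 log units; within the scatter). The acyclic compound 2 stands apart, as a 6.0-fold higher number from compound 1 to compound 2 (0.78 log units; beyond the scatter) and a 6.4-fold lower number from compound 2 to compound 3 (0.81 log units; beyond the scatter) show, so compound 3 sits at the lower end of the three numbers, with compound 1 beside it within the scatter.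

Compound 4 `CCC(CC)Oc1cc([N+](=O)[O-])ccc1N(C)S(C)(=O)=O` is not yet measured. The change from compound 3 is pentan-3-yl in place of cyclopentyl on an oxygen on an aromatic ring. The step that bears on it most is a 6.4-fold lower number from compound 2 to compound 3 (0.81 log units; beyond the scatter), where an acyclic group replaced a ring; pentan-3-yl is acyclic but matches cyclopentyl in the count of carbons, so a smaller move in this assay is expected, upward, landing between compound 3 and compound 2. The expected step is a 2.2-fold higher number from compound 3 to compound 4 (0.33 log units; beyond the scatter). Compound 4 is therefore estimated at 950 nM, within 350 nM to 2600 nM.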

Compound 4, half-maximal inhibitory concentration: 230 nM
Compound 4: the middle estimate sits 4.1-fold (0.62 log units) above what was measured; measured number outside the range, below it.
By their numbers in this assay, from the lowest: compounds 4, 3 and 1 (each within the scatter of the next, the first and the last beyond it); then compound 2.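

A ring on this oxygen is not what set compound 2 apart in this assay: the open-chain pentan-3-yl and the cyclopentyl cannot be told apart here (a 1.9-fold lower number from compound 3 to compound 4 (0.28 log units; within the scatter)), so the high number of compound 2 belongs to isopropyl and not to acyclic groups as a class. Pentan-3-yl in place of isopropyl gives the largest step in the series (a 12-fold lower number from compound 2 to compound 4 (1.09 log units; beyond the scatter)), and pentan-3-yl is also the only group shown to separate from a ring-bearing group, though narrowly (a 2.0-fold lower number from compound 1 to compound 4 (0.31 log units; beyond the scatter)). No measured evidence on why these groups differ is available for this series.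

The compounds shown leave open whether a longer branched chain such as heptan-4-yl holds this level or moves away from it. They also leave open how an ether oxygen or an amine within the group on this oxygen would read.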